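A few compounds are considered here, and "the series" means these few. Any claim that something is new, unique, unknown or untested is made for them only; others in the source may bear on it.

Measured compounds so far:

compound 1 `CCCc1cc(N)c2cc(NC(=O)/C=C/c3ccc(F)cc3)ccc2n1` — 130 nM
compound 2 `CCCc1cc(N)c2cc(NC(=O)/C=C/c3ccccc3)ccc2n1` — 1000 nM
compound 3 `CCCc1cc(N)c2cc(NC(=O)/C=C/c3ccc(N)cc3)ccc2n1` — 190 nM

In an assay on isolated protein for displacement of a labelled ligand from melanin-concentrating hormone receptor 1 (Homo sapiens) (on this read-out higher numbers stand for weaker inhibition and lower numbers for stronger inhibition), compound 3 gives 190 nM, the second highest of the three numbers. The step of a 1.5-fold higher number from compound 1 to compound 3 (0.16 log units; within the scatter) lies within the scatter, so compound 1 and compound 3 cannot be ordered; the step of a 5.3-fold lower number from compound 2 to compound 3 (0.72 log units; beyond the scatter) is beyond it, so compound 2 is the weakest of the three.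

Compound 4 `CCCc1cc(N)c2cc(NC(=O)/C=C/c3cccc(Cl)c3)ccc2n1` is not yet measured. Its change from compound 3 is 3-chlorophenyl in place of 4-aminophenyl on a double-bonded chain carbon bound to a double-bonded chain carbon. Within the data shown here, two measured steps bear on it. The step of a 5.3-fold lower number from compound 2 to compound 3 (0.72 log units; beyond the scatter) shows that the amino on the aromatic carbon lowered the number, so its loss in compound 4 points toward a higher number. The step of a 7.7-fold higher number from compound 1 to compound 2 (0.89 log units; beyond the scatter) shows that a halogen on the aromatic carbon, the fluoro of compound 1, also lowered the number, so the entering chloro may recover part of that. Among the measured compounds shown here, no compound carries a substituent at the position of the 3-chlorophenyl, so the net outcome is uncertain. A modest rise, a 1.8-fold higher number from compound 3 to compound 4 (0.27 log units; within the scatter), is expected. For compound 4 in this assay the estimate is 350 nM, with a range of 110 nM to 1100 nM.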

Compound 4, half-maximal inhibitory concentration: 1100 nM
The estimate for compound 4 lay 3.1-fold (0.50 log units) below the measured number; the range from low to high includes it.
By their numbers in this assay, from the lowest: compounds 1 and 3 (each within the scatter of the next); then compounds 2 and 4 (each within the scatter of the next).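

In this assay, adding the chloro gives a 1.1-fold higher number from compound 2 to compound 4 (0.04 log units; within the scatter) and so stays within the scatter: the 3-chlorophenyl of compound 4 cannot be told apart from the plain phenyl of compound 2. The lower number of the 4-fluorophenyl therefore does not carry over to every halogen-bearing ring, as 3-chlorophenyl in place of 4-fluorophenyl gives an 8.5-fold higher number from compound 1 to compound 4 (0.93 log units; beyond the scatter) and lies beyond the scatter. The swap for 4-aminophenyl gives a 5.8-fold higher number from compound 3 to compound 4 (0.76 log units; beyond the scatter) and also lies beyond it, so at this place on the double-bonded chain carbon, only the two rings substituted at the 4-position stand apart from phenyl.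

As far as these compounds go, whether the halogen or its place on the ring decides the outcome stays open, and 4-chlorophenyl and 3-fluorophenyl would separate the two. Nothing available accounts for these steps.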